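The source may hold more compounds than are shown below. What is called first, only, known or untested is meant among the compounds shown, and "the series" means these compounds.

Of the compounds shown here, three with a shared core have been measured in an assay on a cell-free system (plasma) for antagonist activity at proteinase-activated receptor 4 (Homo sapiens), with a stated time of 5 min, in the presence of a further agent that is not named here; a higher number here means a weaker inhibitor, a lower number a stronger inhibitor. Compound 1 `COc1nn2cc(-c3cc4c(OC)ccc(OC)c4o3)nc2s1` gives 10000 nM in this assay, and compound 2 `COc1nn2cc(-c3cc4ccccc4o3)nc2s1` gives 15000 nM. Compound 3 `COc1cc(OCc2cccc(O)c2)c2cc(-c3cn4nc(OC)sc4n3)oc2c1` gives 2700 nM in this assay, the lowest of the three numbers; its nearest neighbour is compound 1, whose number is higher by a margin beyond the usual scatter, and compound 2 lies further away still. Compound 4 `COc1cc(OCc2cccc(C#N)c2)c2cc(-c3cn4nc(OC)sc4n3)oc2c1` has not yet been measured. It differs from compound 3 in one place only: cyano in place of hydroxy on an aromatic carbon, meta to a large group. No measured pair among these compounds shows this exchange, so no measured step exists to lean on. A small shift in this assay is expected, in either direction, most likely not beyond the scatter. Compound 4 is expected to give an estimated 3000 nM in this assay, with a range from 1000 nM to 9000 nM. The estimated step of a 1.1-fold higher number from compound 3 to compound 4 (0.05 log units; within the scatter) is expected to stay within the scatter.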

Compound 4, half-maximal inhibitory concentration: 820 nM
Compound 4: middle estimate off by 3.7-fold (0.56 log units), on the high side; the whole stated range lies above it.
By their numbers in this assay, from the lowest: compound 4; then compound 3; then compounds 1 and 2 (each within the scatter of the next).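

Cyano in place of hydroxy on the (3-hydroxybenzyl)oxy group gives a 3.3-fold lower number from compound 3 to compound 4 (0.52 log units; beyond the scatter) in this assay and is the first measured change at this place, where the earlier compounds offered no step at all. The hydroxy carries a hydrogen-bond donor and the cyano carries none, so a donor at this place is not needed for a number this low, and the exchange moves the inhibitor in the stronger direction. Nothing measured here explains why the number falls.

From the compounds shown here alone, whether a carboxylic acid or an amine at this same place would lower the number further or raise it remains open. So does whether a cyano on another carbon of this ring would give a similar step, since only this one place appears among these compounds.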